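This account rests on a few compounds, and the source may have more. Where it says the series, first, only, none or still open, it means among the compounds named here.

Among the compounds with values here, compound 2 `COc1ccc(-c2nc(N)c(Oc3ccccc3OC)c(OCCO)n2)cc1` gives 18100 nM in a functional assay on B16 cells (Mus musculus) for cytotoxicity, read by CCK-8 assay, with a stated time of 24 h (on this read-out higher numbers stand for weaker inhibition and lower numbers for stronger inhibition), the lowest of the two numbers measured so far; compound 1 `COc1ccc(-c2nc(N)c(Oc3ccccc3OC)c(Cl)n2)cc1` gives 47800 nM. Within the data shown here, the one measured step, a 2.6-fold lower number from compound 1 to compound 2 (0.42 log units; beyond the scatter), concerns a different part of the shared core and does not touch the group changed here. Compound 3 `COc1ccccc1Oc1c(N)nc(-c2ccc(Br)cc2)nc1OCCO` differs from compound 2 by bromo in place of methoxy on an aromatic carbon. Among the measured compounds shown here, no measured step covers this kind of change, so no step beyond the scatter is expected, a 1.0-fold lower number from compound 2 to compound 3 (0.00 log units; within the scatter). Compound 3 is therefore expected to give about 18000 nM, with a likely range from 6000 nM to 54000 nM.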

Compound 3, half-maximal inhibitory concentration: 11800 nM
Compound 3: middle estimate off by 1.5-fold (0.18 log units), on the high side; measured number inside the range.
By their numbers in this assay, from the lowest: compounds 3 and 2 (each within the scatter of the next); then compound 1.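

Within the data shown here, this is the first comparison at the ring position para to a large group. In this assay, 4-bromophenyl in place of 4-methoxyphenyl gives a 1.5-fold lower number from compound 2 to compound 3 (0.19 log units; within the scatter), so this read-out does not separate bromo from methoxy at this place. No measured evidence is available to explain this result.

From the compounds shown here alone, whether an amine or a carboxylic acid at this place would give a number beyond the scatter remains open. So does whether bromo and methoxy would still match with chloro in place of the 2-hydroxyethoxy group.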